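The compounds below may be only part of what the source reports. "The series", "measured", "known", "first", "only" and "open" are said of these compounds alone.

Of the compounds shown here, three built on one shared core have so far been measured in a functional assay on HEK293 cells for agonist activity at G-protein coupled receptor 39 (Homo sapiens), read by scintillation proximity assay and inositol phosphate accumulation, with a stated time of 75 min; on this read-out higher numbers stand for an effect only at larger amounts of compound and lower numbers for an effect already at smaller amounts. Compound 1 `CCCCCCCCOC1CC(=O)Nc2c1c(C)nn2-c1ncnc2nc[nH]c12` gives 388 nM, compound 2 `Cc1nn(-c2ncnc3nc[nH]c23)c2c1C(NC(=O)Cc1cccs1)CC(=O)N2` gives 244 nM, and compound 3 `Cc1nn(-c2ncnc3nc[nH]c23)c2c1C(C(=O)N(C)c1nccs1)CC(=O)N2` gives 3300 nM, the highest of the three. The step of an 8.5-fold higher number from compound 1 to compound 3 (0.93 log units; beyond the scatter) and the step of a 14-fold higher number from compound 2 to compound 3 (1.13 log units; beyond the scatter) both lie beyond the scatter, so compound 3 is the least potent of the set, whereas the step of a 1.6-fold lower number from compound 1 to compound 2 (0.20 log units; within the scatter) stays within it. Compound 4 `Cc1nn(-c2ncnc3nc[nH]c23)c2c1C(OC(=O)c1ccc(F)cc1)CC(=O)N2` has not yet been measured. It differs from compound 3 in one place: ((4-fluorophenyl)carbonyl)oxy in place of methyl(1,3-thiazol-2-yl)carbamoyl on a saturated ring carbon. The two measured steps that lead into compound 3 show that the methyl(1,3-thiazol-2-yl)carbamoyl group goes with a higher number than either octyloxy or (((thiophen-2-yl)methyl)carbonyl)amino at the same saturated ring carbon. Within the data shown here, removing it is therefore expected to bring the number back down, although the incoming ((4-fluorophenyl)carbonyl)oxy group has no close counterpart among the measured compounds, so the size remains uncertain. For compound 4 the expected step is a 6.6-fold lower number from compound 3 to compound 4 (0.82 log units; beyond the scatter), giving an estimate of 500 nM, with a range from 150 nM to 2000 nM.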

Compound 4, half-maximal effective concentration: 245 nM
Estimate against measurement, compound 4: 2.0-fold (0.31 log units) above; the measured number falls inside the stated range.
By their numbers in this assay, from the lowest: compounds 2, 4 and 1 (each within the scatter of the next); then compound 3.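

At this saturated ring carbon, ((4-fluorophenyl)carbonyl)oxy in place of methyl(1,3-thiazol-2-yl)carbamoyl brings a 13-fold lower number from compound 3 to compound 4 (1.13 log units; beyond the scatter) and so shows that the high number of compound 3 goes with that one group and is not set by the shared core. The new group also sits level with two very different ones, with a 1.0-fold higher number from compound 2 to compound 4 (0.00 log units; within the scatter) against the (((thiophen-2-yl)methyl)carbonyl)amino group and a 1.6-fold lower number from compound 1 to compound 4 (0.20 log units; within the scatter) when (4-fluorophenyl)carbonyl replaces octyl on the same oxygen, so these three groups cannot be told apart here and compound 3 alone stands out.

Still open, on these data alone, is whether the fluorine counts, which a plain benzoyloxy group would test. Also open, as far as these compounds go, is how an amine or a carboxylic acid on this carbon would compare. Nothing at hand gives a reason for any of these steps.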